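The source may report more compounds than this note shows. Statements on the series, on what has been measured and on what is new or still open speak of the compounds shown alone.

Measured compounds:
compound 1, `O=S(=O)(Nc1ccc(-c2nc3ccccc3o2)cc1)c1cccc(F)c1`: > 63000 nM
compound 2, `O=[N+]([O-])c1cc(S(=O)(=O)Nc2ccc3oc(-c4ccccc4)nc3c2)ccc1Cl`: > 63000 nM

In an assay on isolated protein for inhibition of malate dehydrogenase, mitochondrial (Sus scrofa), with stated times of 45 min and 30 min (a higher number here means a weaker inhibitor, a lower number a stronger inhibitor), compound 1 gives > 63000 nM, which is a limit of the assay rather than a measured number. Compound 2 likewise reaches only a limit in this assay, > 63000 nM. Both shown values thus sit at the limit of > 63000 nM in this assay, at which 2 of the 2 values shown sit, so nothing places compound 1 above or below any other compound. Compound 3, `O=S(=O)(Nc1ccc(-c2nc3ccccc3o2)cc1)c1ccc(Cl)c(Cl)c1`, has not yet been measured in this assay; it carries 3,4-dichlorophenyl in place of 3-fluorophenyl on a sulfonyl sulfur. Among the compounds with values here, no step between measured compounds is known here, so a change from compound 1 beyond the usual scatter cannot be foreseen in either direction. Compound 3 is therefore expected to give about 80000 nM in this assay, within 20000 nM to 300000 nM, and the expected step that the limit leaves unreadable from compound 1 to compound 3 is none beyond the scatter.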

Compound 3, half-maximal inhibitory concentration: > 63000 nM
Compound 3: a limit, no number (the forecaster's own chance of this, stated with the estimate: 75%); the middle value does not contradict the limit.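

Within the data shown here, compound 1 and compound 3 both reach only a limit in this assay, so no step between them can be read: the limit of > 63000 nM in this assay, at which 3 of the 3 values shown sit. The compounds shown leave open what change, if any, would give a measurable value.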